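The source may hold more compounds than are shown below. What is called first, only, known or untested is meant among the compounds shown, and "the series" means these compounds.

Compound 2, with structure `Cc1ccc(C)c(/C=C(\C(=O)c2ccc(Cl)cc2)S(=O)(=O)c2ccc(Br)cc2)c1`, is one of three close relatives in this set. In a functional assay on DU-145 cells (Homo sapiens) for inhibition, read by trypan blue exclusion, with a stated time of 96 h (on this read-out lower numbers stand for stronger inhibition of growth and higher numbers for weaker inhibition of growth), compound 2 gives 1000 nM. Compound 3, `Cc1ccc(CS(=O)(=O)/C(=C/c2cc(C)ccc2C)C(=O)c2ccc(Cl)cc2)cc1`, gives 1000 nM in this assay, and compound 1, `Cc1ccc(C)c(/C=C(\C(=O)c2ccc(Cl)cc2)S(=O)(=O)Cc2ccc(Cl)cc2)c1`, gives 10000 nM. Compound 2 stands level with compound 3 at the digits printed, and the two share the lowest number of the three; the step of a 10-fold lower number from compound 1 to compound 2 (1.00 log units; beyond the scatter) and the step of a 10-fold lower number from compound 1 to compound 3 (1.00 log units; beyond the scatter) both set compound 1 apart, while no change at the digits printed from compound 2 to compound 3 (within the scatter).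

Compound 4, `CN(C)c1ccc(/C=C(\C(=O)c2ccc(Cl)cc2)S(=O)(=O)c2ccc(Br)cc2)cc1`, differs from compound 2 in one place: 4-(dimethylamino)phenyl in place of 2,5-dimethylphenyl on a double-bonded chain carbon bound to a double-bonded chain carbon. Going by the values given here, none of the measured steps touches this part of the shared core. The change from compound 1 to compound 2 and that from compound 2 to compound 3 alter the group on the sulfonyl sulfur, and the change from compound 1 to compound 3 alters a substituent on that same group. The ring attached to the double-bonded chain carbon is the same in all three measured compounds, so the measured numbers give no direct guide for compound 4.

Among the compounds with values here, with no step to lean on, the expectation for compound 4 is simply that it stays near compound 2, and the step of no change at the digits printed from compound 2 to compound 4 (within the scatter) is estimated to fall within the scatter. Compound 4 is therefore expected to give about 1000 nM, with a wide range from 200 nM to 5000 nM.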

Compound 4, concentration for 50% growth inhibition: > 100000 nM
Compound 4 ended at the assay's limit; the forecaster's own chance of this, stated with the estimate: 10%; middle value at least 100-fold (2.00 log units) away from the limit.
By their numbers in this assay, from the lowest: compounds 2 and 3 (each within the scatter of the next); then compound 1. At a limit, above all of these: compound 4.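

In this assay compound 4 gives > 100000 nM, which is a limit of the assay and not a number, and no other compound shown sits there: the limit of > 100000 nM in this assay, at which 1 of the 4 values shown sits.

Going by these compounds alone, the ring on the double-bonded chain carbon, unchanged across the earlier compounds, now proves to matter, since putting 4-(dimethylamino)phenyl in place of 2,5-dimethylphenyl gives an at least 100-fold higher number from compound 2 to compound 4 (2.00 log units; beyond the scatter). The changes at the sulfonyl sulfur, such as a 10-fold lower number from compound 1 to compound 2 (1.00 log units; beyond the scatter), are modest by comparison, so among these compounds growth inhibition depends more on this ring than on the group at the sulfonyl sulfur, though that rests on this single change.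

This one step swaps two things at once, removing the two methyl groups and bringing in the dimethylamino group, so it cannot tell which of them accounts for the loss of inhibition. On these data alone, how a plain phenyl, or a phenyl carrying a methoxy group or a primary amine, would behave on the same carbon remains open, and such groups could help separate those two parts of the change.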